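A few compounds are considered here, and "the series" means these few. Any claim that something is new, unique, unknown or untested is made for them only; others in the source may bear on it.

Measured so far in a functional assay on MGC-803 cells (Homo sapiens) for inhibition, read by MTT assay, with a stated time of 48 h; on this read-out higher numbers stand for weaker inhibition and lower numbers for stronger inhibition:
- compound 1 `C/C=C/C(=O)N(Cc1ccc(OC)c([N+](=O)[O-])c1)c1cc(OC)c(OC)c(OC)c1` gives 590 nM
- compound 2 `COc1ccc(CNc2cc(OC)c(OC)c(OC)c2)cc1F` gives 39700 nM
- compound 3 `COc1ccc(CNc2cc(OC)c(OC)c(OC)c2)cc1C` gives 56800 nM

Compound 2 sits with compound 3 at the high end of these numbers, and compound 1 lies far lower than both. Next in line is compound 4 `C/C=C/C(=O)N(Cc1ccc(OC)c(F)c1)c1cc(OC)c(OC)c(OC)c1`, which differs from compound 2 by one change: (prop-1-en-1-yl)carbonyl in place of hydrogen on a nitrogen on an aromatic ring. This puts (prop-1-en-1-yl)carbonyl in place of hydrogen on the nitrogen.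

Among the compounds with values here, the only measured step, a 1.4-fold higher number from compound 2 to compound 3 (0.16 log units; within the scatter), concerns an aromatic carbon and leaves this nitrogen untouched, so it gives no size for the change. Within the data shown here, the nearest guide is compound 1 at 590 nM as the only measured compound carrying this group on nitrogen, although it also has a nitro group where compound 2 has fluoro. The two changes cannot be separated on these data. A large move to a lower number is therefore expected, beyond the scatter, and the estimated step is a 44-fold lower number from compound 2 to compound 4 (1.64 log units; beyond the scatter) in this assay overall. Compound 4 is estimated at 900 nM, with a range of 150 nM to 6000 nM expected.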

Compound 4, half-maximal inhibitory concentration: 1650 nM
Compound 4: the middle estimate sits 1.8-fold (0.26 log units) below what was measured; low and high end bracket the measured number.
By their numbers in this assay, from the lowest: compound 1; then compound 4; then compounds 2 and 3 (each within the scatter of the next).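

In this assay, (prop-1-en-1-yl)carbonyl in place of hydrogen on the nitrogen now has a size of its own, a 24-fold lower number from compound 2 to compound 4 (1.38 log units; beyond the scatter), with fluoro held constant on the aromatic carbon. The two differences carried by compound 1 can therefore be read apart: with the group on the nitrogen in place, fluoro in place of nitro gives a 2.8-fold higher number from compound 1 to compound 4 (0.45 log units; beyond the scatter), a much smaller step that still lies beyond the scatter. No measurement bears on why either step occurs.

Going by these compounds, it remains open whether the step on the nitrogen needs the double bond, which a butanoyl or a shorter acetyl group would test. Also open, on these data alone, is how the amide series responds on the aromatic carbon to other groups, such as methyl, an amine or a carboxylic acid.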